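The source may report more compounds than this note shows. Statements on the series, on what has been measured and on what is new or still open speak of the compounds shown alone.

Of the compounds shown here, three built on one shared core have been measured in a functional assay on MDA-MB-231 cells (Homo sapiens) for cytotoxicity, read by MTT assay, with a stated time of 48 h; a lower number here means a stronger inhibitor, a higher number a weaker inhibitor. Compound 1 `Cc1cccc(Cn2cc(COc3ccc4c(=O)ccoc4c3)nn2)c1` gives 16000 nM in this assay. Compound 2 `O=c1ccoc2cc(OCc3cn(Cc4ccc(F)cc4)nn3)ccc12` reaches only the limit of the assay in this assay, reported as > 100000 nM. Compound 3 `CC(C)(C)c1ccc(Cn2cc(COc3ccc4c(=O)ccoc4c3)nn2)cc1` likewise stops at the limit of this assay, given as > 100000 nM. Among the compounds with values here, the only step that can be read in size is an at least 6.2-fold higher number from compound 1 to compound 2 (0.79 log units; beyond the scatter), while a step that the two limits leave unreadable from compound 2 to compound 3 cannot be read, and both of those weaker compounds sit at the limit of > 100000 nM in this assay, at which 2 of the 3 values shown sit.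

Compound 2 therefore stands at the limit of the numbers shown, with no value of its own to anchor a step. The change now considered is 3-cyanophenyl in place of 4-fluorophenyl on a saturated chain carbon bound to an aromatic nitrogen, giving compound 4 `N#Cc1cccc(Cn2cc(COc3ccc4c(=O)ccoc4c3)nn2)c1`. Within the data shown here, of the measured steps, only the one from compound 1 to compound 2 touches the same place, and it showed that moving from a 3-methylphenyl to a 4-fluorophenyl cost potency beyond the scatter. Compound 4 carries its substituent again in the 3-position of the phenyl, so compound 4 is expected to return toward the region of compound 1, whose value is 16000 nM, with the step estimated as an at least 2.5-fold lower number from compound 2 to compound 4 (0.39 log units; beyond the scatter). The estimate for compound 4 in this assay is 40000 nM, expected to lie between 10000 nM and 100000 nM.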

Compound 4, half-maximal inhibitory concentration: > 100000 nM
Compound 4 ended at the assay's limit (the forecaster's own chance of this, stated with the estimate: 40%); middle value at least 2.5-fold (0.39 log units) away from the limit.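

The 3-cyanophenyl of compound 4 does not keep the activity of the 3-methylphenyl of compound 1, even though only the group on the aromatic carbon differs: cyano in place of methyl gives an at least 6.2-fold higher number from compound 1 to compound 4 (0.79 log units; beyond the scatter) in this assay. Within the data shown here, the result for compound 4 is a limit of the assay, and the steps that join two such limits, including the one to compound 2, cannot be read. At this position, a 3-substituted benzyl therefore does not by itself give a readable value, and compound 1 remains the only compound of the four with a number rather than a limit: the limit of > 100000 nM in this assay, at which 3 of the 4 values shown sit.

On these data alone, how far compound 2, compound 3 and compound 4 lie from one another stays open, since all three end at a limit, and with only compound 1 giving a number, no trend across the benzyl groups can be drawn. Also open, as far as these compounds go, is whether an amine or a carboxylic acid in place of the methyl of compound 1, or a longer chain between the phenyl and the aromatic nitrogen, would give a value that can be read.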